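Chloro in place of hydrogen, two places in one series

The compounds below may be only part of what the source reports. "The series", "measured", "known", "first", "only" and "open" are said of these compounds alone.

Of the compounds shown here, three have been measured in a physicochemical assay for lipophilicity; on this read-out higher numbers stand for higher lipophilicity and lower numbers for lower lipophilicity. Compound 1 `Cc1cc(C#N)cc(C)c1Oc1ccnc(Nc2ccc(C#N)cc2)n1` gives 1.39. Compound 2 `Cc1cccc(C)c1Nc1ccnc(Nc2ccc(C#N)cc2)n1` gives 1.49, and compound 3 `Cc1cc(Cl)cc(C)c1Nc1ccnc(Nc2ccc(C#N)cc2)n1` gives 1.27. The gap between compound 1 and compound 2, and that between compound 1 and compound 3, both lie within the scatter, so no order among the three is read from these numbers. How the core of compound 1 differs from the core of compound 2 is not broken down here.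

One change is seen twice. From compound 2 to compound 3 the change is chloro in place of hydrogen on an aromatic carbon, and in this assay the step is a number 0.22 log units lower from compound 2 to compound 3 (within the scatter). Compound 4 `Cc1cc(C#N)cc(C)c1Oc1nc(Nc2ccc(C#N)cc2)ncc1Cl` carries the change chloro in place of hydrogen on an aromatic carbon relative to compound 1. The place is not the same: in compound 3 the chloro sits on a ring of carbon only, meta to two methyl groups and para to a large group, while in compound 4 it sits on a ring with two nitrogen, ortho to a large group, two atoms from the ring nitrogen and para to the (4-cyanophenyl)amino group. It is therefore the same kind of change, not the same change.

Among the measured compounds shown here, the step from compound 1 to compound 4 is expected to be about a number 0.09 log units lower from compound 1 to compound 4 (within the scatter) in this assay, beside the measured one, resting on the single step from compound 2 to compound 3 being a number 0.22 log units lower from compound 2 to compound 3 (within the scatter) and on the two places differing. Compound 4 is estimated at 1.3, between 0.9 and 1.8.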

Compound 4, partition coefficient: 1.29
Estimate against measurement, compound 4: 0.01 log units above, within the range that was stated.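

In this assay the new step is a number 0.10 log units lower from compound 1 to compound 4 (within the scatter) and the earlier step of the same kind is a number 0.22 log units lower from compound 2 to compound 3 (within the scatter) so for chloro in place of hydrogen on an aromatic carbon, neither of the two pairs gives a step beyond the scatter. This does not show that the change carries from one core to another as a fixed step: the chloro stands on a ring of carbon only in compound 3 and on a ring with two nitrogen in compound 4, so core and place differ together, and two steps within the scatter fix no size for the change. Nothing measured here bears on why the two steps read as they do.

The compounds shown leave open whether chloro on the same kind of ring and in the same place would read alike on the core of compound 1 and the core of compound 2. They also leave open how an amine or a carboxylic acid in place of that hydrogen would read, and whether either would give a step beyond the scatter.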